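From chloro to trifluoromethyl: what compound 3 may show

This account rests on a few compounds, and the source may have more. Where it says the series, first, only, none or still open, it means among the compounds named here.

compound 1 `NCC1CCN(c2c(F)cc3c(=O)c(C(=O)O)cn(C4CC4)c3c2C(F)(F)F)C1`: 38 ug/mL
compound 2 `CC1CN(c2c(F)cc3c(=O)c(C(=O)O)cn(C4CC4)c3c2Cl)CCN1`: 45 ug/mL

Both values come from a functional assay on V79 cells (Cricetulus griseus) for cytotoxicity, read by colony formation; on this read-out lower numbers stand for stronger inhibition and higher numbers for weaker inhibition. Compound 2 stands within the usual scatter of compound 1, so these two numbers cannot be told apart. Compound 3 `CC1CN(c2c(F)cc3c(=O)c(C(=O)O)cn(C4CC4)c3c2C(F)(F)F)CCN1` keeps the 3-methylpiperazin-1-yl group of compound 2 and differs from it in one place: trifluoromethyl in place of chloro on an aromatic carbon. Trifluoromethyl takes the place of chloro on an aromatic carbon, ortho to that 3-methylpiperazin-1-yl group. For the measured compounds named here, no pair of measured compounds shows this swap on its own, so its size has not been observed directly. Compound 1 also carries a trifluoromethyl group and gives 38 ug/mL, so no step beyond the scatter is expected in this assay, in either direction. The expected change is a 1.1-fold lower number from compound 2 to compound 3 (0.05 log units; within the scatter). Compound 3 is estimated at 40 ug/mL, with an expected range of 16 ug/mL to 100 ug/mL.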

Compound 3, half-maximal inhibitory concentration: 220 ug/mL
Compound 3: the middle estimate sits 5.5-fold (0.74 log units) below what was measured; measured number outside the range, above it.
By their numbers in this assay, from the lowest: compounds 1 and 2 (each within the scatter of the next); then compound 3.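

In this assay, trifluoromethyl in place of chloro on this aromatic carbon, ortho to a 3-methylpiperazin-1-yl group, gives a 4.9-fold higher number from compound 2 to compound 3 (0.69 log units; beyond the scatter) and so points to weaker inhibition. The trifluoromethyl group does not fix the number by itself: with it held in place, 3-methylpiperazin-1-yl in place of 3-(aminomethyl)pyrrolidin-1-yl gives a 5.8-fold higher number from compound 1 to compound 3 (0.76 log units; beyond the scatter) and also points to weaker inhibition. No measurement at hand explains either step.

On these data alone, it remains open whether other groups on this carbon, such as methyl, methoxy or a nitrile, would read like chloro or like trifluoromethyl. Also open, as far as these compounds go, is whether the swap from chloro to trifluoromethyl would give a similar step with 3-(aminomethyl)pyrrolidin-1-yl in the place of 3-methylpiperazin-1-yl.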